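The source may report more compounds than this note shows. Statements on the series, on what has been measured and on what is new or still open speak of the compounds shown alone.

Measured compounds:
Compound 1, `O=C(CSc1ncccn1)N/N=c1/scc(-c2ccc(F)cc2)n1-c1ccccc1`: 110 ug/mL
Compound 2, `Cc1nnc(SCC(=O)N/N=c2/scc(-c3ccc([N+](=O)[O-])cc3)n2-c2ccccc2)s1`: "not determined" (no result reported)
Compound 3, `Cc1ccc(-c2cs/c(=N/NC(=O)CSc3ncccn3)n2-c2ccccc2)cc1`: 85 ug/mL

In a functional assay on C6 cells (Rattus norvegicus) for cytotoxicity, read by MTT assay, with a stated time of 24 h (a lower number here means a stronger inhibitor, a higher number a weaker inhibitor), compound 3 gives the lowest of the two numbers available; its nearest neighbour is compound 1, and the step of a 1.3-fold lower number from compound 1 to compound 3 (0.11 log units; within the scatter) lies within the scatter, so the two compounds cannot be ordered. Compound 2 has no result in this assay.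

Compound 4, `Cc1ccc(-c2cs/c(=N/NC(=O)CSc3nnc(C)s3)n2-c2ccccc2)cc1`, differs from compound 3 in one place: 5-methyl-1,3,4-thiadiazol-2-yl in place of pyrimidin-2-yl on a sulfur

For the measured compounds named here, none of the measured steps touches this sulfur-linked heteroaryl group. Going by the values given here, the only measured step, a 1.3-fold lower number from compound 1 to compound 3 (0.11 log units; within the scatter), concerns methyl in place of fluoro on an aromatic carbon and is within the scatter. Among the compounds with values here, compound 2, the one measured compound that carries the 5-methyl-1,3,4-thiadiazol-2-yl group, has no number, so the data give no measured guide to the exchange. For compound 4 a step of no change at the digits printed from compound 3 to compound 4 (within the scatter) is therefore expected, that is, no change beyond the scatter. Compound 4 is estimated at 85 ug/mL in this assay, with a range of 40 ug/mL to 180 ug/mL.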

Compound 4, half-maximal inhibitory concentration: 25.3 ug/mL
Compound 4: middle estimate off by 3.4-fold (0.53 log units), on the high side; the measured number lies below the stated range.
By their numbers in this assay, from the lowest: compound 4; then compounds 3 and 1 (each within the scatter of the next).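

For the compounds shown here, the sulfur-linked heteroaryl group proves to be a place where a change moves the number in this assay: 5-methyl-1,3,4-thiadiazol-2-yl in place of pyrimidin-2-yl gives a 3.4-fold lower number from compound 3 to compound 4 (0.53 log units; beyond the scatter), while the only earlier step, on an aromatic carbon, stayed within the scatter. The size of the group does not differ, at 6 heavy atoms on each side, so this step comes with a change of ring and of its atoms and not with a larger group. No measurement shown here accounts for the step.

From the compounds shown here alone, whether the ring or its methyl carries the step stays open, as does what a 1,3,4-thiadiazol-2-yl bearing an amine in place of the methyl would give. Also open, going by these compounds, is whether the same exchange would give a like step starting from compound 1.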